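The source may hold more compounds than are shown below. What is called first, only, known or untested is meant among the compounds shown, and "the series" means these compounds.

Measured compounds:
compound 1, `CCSc1nnc(Cc2ccccc2Oc2ccccc2)[nH]1`: 169%
compound 2, `CCCSc1nnc(Cc2ccccc2Oc2ccccc2)[nH]1`: 158%
compound 3, `CCSc1nnc(Cc2ccc(Cl)cc2Oc2ccccc2F)[nH]1`: 141%

All three were tested in a functional assay on the whole organism (strain NMRI) with Mus musculus as the target, with a stated time of 60 min, at a dose of 20 mg/kg by the intraperitoneal route; a lower number here means a weaker effect, a higher number a stronger effect of the compound at the dose given. Compound 1 and compound 2 share one core and differ by a single change, (methyl in place of hydrogen on a saturated chain carbon, two bonds along the chain from a sulfur). That change made the step of a number 11 percentage points lower from compound 1 to compound 2 (beyond the scatter). Compound 3 carries another core; how the core of compound 3 differs from the core of compound 1 is not broken down here. In this assay compound 3 gives the lowest of the three numbers, and its gaps to compound 2 and to compound 1 are both beyond the scatter.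

Compound 4, `CCCSc1nnc(Cc2ccc(Cl)cc2Oc2ccccc2F)[nH]1`, is not yet measured. Among the measured compounds shown here, it differs from compound 3 by methyl in place of hydrogen on a saturated chain carbon, two bonds along the chain from a sulfur, which is the same change as the one from compound 1 to compound 2, at the same place. The change has been seen once only, on the other core, so the expectation rests on one step. For compound 4 a step of about that size is expected, a number 11 percentage points lower from compound 3 to compound 4 (beyond the scatter), because the earlier one read a number 11 percentage points lower from compound 1 to compound 2 (beyond the scatter). Compound 4 is therefore estimated at 130%, with 115% and 147% as the ends of the expected range.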

Compound 4, a percentage reported as activity, at one dose (the size of the read-out at that dose, not a potency): 133%
The estimate for compound 4 lay 3 percentage points below the measured number, and the stated range covers the measured number.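

On the core of compound 3, ethylsulfanyl to propylsulfanyl in this assay gives a number 8 percentage points lower from compound 3 to compound 4 (within the scatter), and this step alone cannot be told apart from repeat scatter. Set beside the earlier step, the change shows no detectable difference between the two cores: the same change on two cores in this assay, a number 11 percentage points lower (beyond the scatter) from compound 1 to compound 2 and a number 8 percentage points lower (within the scatter) from compound 3 to compound 4, 3 percentage points apart, within the scatter of two such steps. This does not show that the change would carry to further cores, as it rests on two cores in one assay at a single dose, nor does it establish a real drop on the core of compound 3.

Open, from the compounds shown here alone, is how the read-out would move if a longer chain, such as butyl, or an amine or a carboxylic acid took the place of propyl. Also open is which part of the difference between the core of compound 1 and the core of compound 3 goes with the gap in their values; no pair shown isolates a single part of it.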